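Chloro in Place of Fluoro: Compound 2 to Compound 3

The compounds below may be only part of what the source reports. "The series", "measured", "known", "first", "only" and "open" are said of these compounds alone.

compound 1 `O=S(=O)(c1ccc(F)c(F)c1)c1cnc2c(F)cccc2c1-c1ccc(Cl)cc1` — 13 nM
compound 2 `O=S(=O)(c1ccc(F)c(F)c1)c1cnc2cc(F)ccc2c1-c1ccc(Cl)cc1` — 22 nM

Of the compounds shown here, two have been measured in a functional assay on cells for negative allosteric modulation of metabotropic glutamate receptor 5 (Homo sapiens), read by fluorescence and calcium flux, with a stated time of 20 min; on this read-out lower numbers stand for stronger inhibition and higher numbers for weaker inhibition. Compound 1 gives 13 nM and compound 2 gives 22 nM. Compound 2 has the higher of the two numbers, yet its gap to compound 1 lies within the scatter, so no order between them can be claimed. Compound 3 `O=S(=O)(c1ccc(F)c(Cl)c1)c1cnc2cc(F)ccc2c1-c1ccc(Cl)cc1` differs from compound 2 in one place: chloro in place of fluoro on an aromatic carbon. Going by the values given here, no pair of measured compounds shows a step of this kind, so there is no measured step on which to rest an expectation, and the two values in hand say nothing about it. The step in this assay is therefore expected to be small, in either direction, and not beyond the scatter: the expected step is a 1.1-fold lower number from compound 2 to compound 3 (0.04 log units; within the scatter). Compound 3 is estimated at 20 nM, with a range from 7 nM to 60 nM.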

Compound 3, half-maximal inhibitory concentration: 27 nM
Compound 3: the middle estimate sits 1.4-fold (0.13 log units) below what was measured; measured number inside the range.
By their numbers in this assay, from the lowest: compounds 1, 2 and 3 (each within the scatter of the next, the first and the last beyond it).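

Chloro in place of fluoro on this aromatic carbon, ortho to a fluoro group and meta to a large group, gives a 1.2-fold higher number from compound 2 to compound 3 (0.09 log units; within the scatter) in this assay and is the only step measured at this position among the compounds shown. The position therefore holds chloro as well as fluoro with no readable change on this read-out, so the 3-chloro-4-fluorophenyl group cannot be told apart from the 3,4-difluorophenyl group here. No independent measurement is available that bears on this result.

From the compounds shown here alone, whether a methyl group, a methoxy group or an amine on this carbon would also leave the number within the scatter remains open. So does whether chloro in place of the remaining fluoro on that ring would give a step of similar size.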